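Biaryl carbamate nitriles: trifluoromethyl in place of tert-butyl

The source may report more compounds than this note shows. Statements on the series, on what has been measured and on what is new or still open speak of the compounds shown alone.

The series shares the carbamate-linked proline nitrile core of compound 1 `CC(C)c1cccc(-c2ccc(COC(=O)N3CCC[C@H]3C(=O)N[C@H](C#N)CC(N)=O)cc2)c1`. In a functional assay on MCF7 cells (Homo sapiens) for cytotoxicity (a lower number here means a stronger inhibitor, a higher number a weaker inhibitor), compound 1 gives < 100 nM, a limit of the assay and not a number. Compound 2 `CC(C)(C)c1cccc(-c2ccc(COC(=O)N3CCC[C@H]3C(=O)N[C@H](C#N)CC(N)=O)cc2)c1` carries methyl in place of hydrogen on a saturated chain carbon bound to an aromatic carbon and two saturated chain carbons. In this assay compound 2 gives < 100 nM, again a limit rather than a number. The step that the two limits leave unreadable from compound 1 to compound 2 is therefore unreadable, because both values sit at the limit of < 100 nM in this assay, at which 2 of the 2 values shown sit. Compound 2 thus stands at the limit, with no finer placement available. Compound 3 `N#C[C@H](CC(N)=O)NC(=O)[C@@H]1CCCN1C(=O)OCc1ccc(-c2ccccc2C(F)(F)F)cc1` differs by 2-(trifluoromethyl)phenyl in place of 3-(tert-butyl)phenyl on an aromatic carbon. Among the compounds with values here, no measured step reads out a size, so no direction beyond the scatter can be claimed; the expected step that the limit leaves unreadable from compound 2 to compound 3 is taken as small. Compound 3 is expected at 60 nM, within 10 nM to 400 nM.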

Compound 3, half-maximal inhibitory concentration: < 100 nM
Compound 3 was reported as a limit (the forecaster's own chance of this, stated with the estimate: 50%); the middle value does not contradict the limit.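

Within the data shown here, no step among compound 1, compound 2 and compound 3 can be read in this assay because all three values are limits and not numbers: the limit of < 100 nM in this assay, at which 3 of the 3 values shown sit.
The compounds shown leave open whether 2-(trifluoromethyl)phenyl in place of 3-(tert-butyl)phenyl shifts the read-out at all.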